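A few compounds are considered here, and "the series" means these few. Any claim that something is new, unique, unknown or untested is made for them only; others in the source may bear on it.

Compound 1 `COc1cccc(OC)c1C(=O)Nc1nnc(-c2ccc(C)cc2)s1` gives 1230 nM in a functional assay on the whole organism (integument) for inhibition, with Chilo suppressalis as the target, read by scintillation counting, with a stated time of 72 h; a lower number here means a stronger inhibitor, a higher number a weaker inhibitor. Compound 2 `COc1cccc(OC)c1C(=O)Nc1nnc(-c2ccc(C(C)C)cc2)s1` gives 398 nM. Compound 3 `COc1cccc(OC)c1C(=O)Nc1nnc(-c2ccc(F)cc2)s1` gives 97.7 nM.

Compound 3 shows the lowest number of the three, separated from compound 2 by a 4.1-fold lower number from compound 2 to compound 3 (0.61 log units; beyond the scatter) and from compound 1 by a 13-fold lower number from compound 1 to compound 3 (1.10 log units; beyond the scatter). Compound 4 `COc1cccc(OC)c1C(=O)Nc1nnc(-c2ccc(C(F)(F)F)cc2)s1` differs from compound 3 by trifluoromethyl in place of fluoro on an aromatic carbon. For the measured compounds named here, no measured step exchanges fluoro for trifluoromethyl, so the closest guide is the size of the group on that carbon: a 3.1-fold lower number from compound 1 to compound 2 (0.49 log units; beyond the scatter) and a 4.1-fold lower number from compound 2 to compound 3 (0.61 log units; beyond the scatter) both lie beyond the scatter, but the larger group improved the number in one and worsened it in the other. Compound 4 is therefore expected to stay near compound 3, with a modest step of a 2.0-fold higher number from compound 3 to compound 4 (0.31 log units; beyond the scatter) estimated, and a value of 200 nM expected, between 60 nM and 700 nM.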

Compound 4, half-maximal inhibitory concentration: 49 nM
Estimate against measurement, compound 4: 4.1-fold (0.61 log units) above, and the stated range ends above it.
By their numbers in this assay, from the lowest: compounds 4 and 3 (each within the scatter of the next); then compound 2; then compound 1.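

In this assay, fluoro and trifluoromethyl on this aromatic carbon cannot be told apart, with a 2.0-fold lower number from compound 3 to compound 4 (0.30 log units; within the scatter), even though trifluoromethyl enters with more heavy atoms. Compound 4 stands clearly apart from the two compounds with hydrocarbon groups at this position, with an 8.1-fold lower number from compound 2 to compound 4 (0.91 log units; beyond the scatter) and a 25-fold lower number from compound 1 to compound 4 (1.40 log units; beyond the scatter), so among these four compounds the two fluorine-bearing groups give the lowest numbers. Nothing measured here offers a reason for this.

The compounds shown leave open whether chloro, methoxy or nitrile on the same carbon would join compounds 3 and 4 or fall nearer compounds 1 and 2. They also leave open how an amine or a carboxylic acid there would read.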